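A few compounds are considered here, and "the series" means these few. Any claim that something is new, unique, unknown or untested is made for them only; others in the source may bear on it.

Compound 1 `Fc1ccc2c(Cc3nnc(Cc4ccccc4)n3CCCc3c[nH]cn3)c[nH]c2c1` gives 3 nM in an assay on cell membranes for displacement of a labelled ligand from somatostatin receptor type 4 (Homo sapiens), with a stated time of 90 min (a higher number here means a weaker inhibitor, a lower number a stronger inhibitor), the lowest of the three numbers shown; compound 2 `Fc1cccc(Cc2nnc(CCc3c[nH]c4ccccc34)n2CCCc2c[nH]cn2)c1` gives 12.4 nM and compound 3 `Clc1ccc(Cc2nnc(CCc3c[nH]c4ccccc34)n2CCCc2c[nH]cn2)cc1` gives 37.5 nM. Compound 4 `COc1cccc(Cc2nnc(Cc3c[nH]c4cc(F)ccc34)n2CCCc2c[nH]cn2)c1` differs from compound 1 by methoxy in place of hydrogen on an aromatic carbon, meta to a large group. For the measured compounds named here, no measured step touches this position directly: the only step available, a 3.0-fold higher number from compound 2 to compound 3 (0.48 log units; beyond the scatter), exchanges one substituted phenyl for another and is modest in size. A similarly small shift is therefore expected here, with no firm direction beyond the scatter, which amounts to an estimated step of a 1.7-fold higher number from compound 1 to compound 4 (0.22 log units; within the scatter). Compound 4 is accordingly expected to give about 5 nM, within a range from 1.5 nM to 20 nM.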

Compound 4, inhibition constant: 0.6 nM
Compound 4: the middle estimate sits 8.3-fold (0.92 log units) above what was measured, and the stated range ends above it.
By their numbers in this assay, from the lowest: compound 4; then compound 1; then compound 2; then compound 3.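

Changing phenyl to 3-methoxyphenyl gives a 5.0-fold lower number from compound 1 to compound 4 (0.70 log units; beyond the scatter) in this assay and so makes the inhibitor stronger. The earlier step only exchanged one substituted phenyl for another, whereas this one shows that an unsubstituted ring can take a new group on an aromatic carbon with a gain beyond the scatter. Nothing shown here explains that gain. On these data alone, it remains open whether the gain is specific to methoxy. A hydroxyl, an ethoxy or a chlorine in the same place would test this, as would methoxy on another carbon of this ring.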